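This account rests on a few compounds, and the source may have more. Where it says the series, first, only, none or still open, it means among the compounds named here.

Three compounds share one core and differ either in the length of the saturated chain or in the group on an aromatic carbon. In a functional assay on SW480 cells (Homo sapiens) for antiproliferative activity, read by MTT assay, with a stated time of 48 h (a higher number here means a weaker inhibitor, a lower number a stronger inhibitor), compound 1 `CCCCCCCC(CCO)n1cnc2c(NC)ncnc21` gives 15300 nM. Compound 2 `CCCCCCCCC(CCO)n1cnc2c(Cl)ncnc21` gives 1370 nM in this assay. Compound 3 `CCCCCCCCC(CCO)n1cnc2c(NC)ncnc21` gives 3770 nM in this assay, which places it second highest of the three numbers, with compound 2 nearest and compound 1 furthest. Two steps connect it to the others: a 4.1-fold lower number from compound 1 to compound 3 (0.61 log units; beyond the scatter) and a 2.8-fold higher number from compound 2 to compound 3 (0.44 log units; beyond the scatter).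

Compound 4 `CCCCCCCCCC(CCO)n1cnc2c(NC)ncnc21` has not yet been measured. It differs from compound 3 by methyl in place of hydrogen on a saturated chain carbon, nine bonds along the chain from an aromatic nitrogen. Among the compounds with values here, the only measured step that bears on this change is a 4.1-fold lower number from compound 1 to compound 3 (0.61 log units; beyond the scatter), where the same kind of addition, at the place eight bonds along the chain from an aromatic nitrogen, lowered the number. The step of a 2.8-fold higher number from compound 2 to compound 3 (0.44 log units; beyond the scatter) concerns the group on the aromatic carbon and does not speak to chain length. A single lengthening is all that is shown, so whether a second one continues the trend is uncertain, but a further fall of somewhat smaller size is the natural expectation. The expected step is a 2.1-fold lower number from compound 3 to compound 4 (0.32 log units; beyond the scatter). Compound 4 is therefore estimated at 1800 nM in this assay, with a range from 700 nM to 4500 nM.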

Compound 4, half-maximal inhibitory concentration: 4450 nM
For compound 4 the middle estimate is 2.5-fold (0.39 log units) below the measured one; low and high end bracket the measured number.
By their numbers in this assay, from the lowest: compound 2; then compounds 3 and 4 (each within the scatter of the next); then compound 1.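

In this assay, adding a methyl at the place nine bonds along the chain from an aromatic nitrogen gives a 1.2-fold higher number from compound 3 to compound 4 (0.07 log units; within the scatter) and so leaves the two compounds indistinguishable, whereas the same kind of addition at the place eight bonds along the chain gave a 4.1-fold lower number from compound 1 to compound 3 (0.61 log units; beyond the scatter) in the step before. Taken together, the two additions still amount to a 3.4-fold lower number from compound 1 to compound 4 (0.54 log units; beyond the scatter) for these three methylamino compounds, so the longer chains keep their lower numbers, but the fall seen with the first addition does not continue with the second. Nothing measured here accounts for this levelling off.

Within the data shown here, whether a still longer chain would leave the number level, lower it or raise it remains open, since the trend rests on only three chain lengths. It is also unknown whether chloro in place of methylamino would change the number on the chain of compound 4 as it does on the chain of compound 3, or what an amine in place of the hydroxyl would do.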